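A few compounds are considered here, and "the series" means these few. Any claim that something is new, unique, unknown or untested is made for them only; others in the source may bear on it.

Three measured compounds share one core and differ only in the aryl group on the carbon that is double-bonded to nitrogen. In a functional assay on HT-29 cells (Homo sapiens) for cytotoxicity, read by MTT assay, with a stated time of 72 h (on this read-out lower numbers stand for stronger inhibition and higher numbers for weaker inhibition), compound 1 `CN(C)CCn1cnnc1-c1cc(Oc2ccc(NC(=O)N/N=C/c3c[nH]c4ccccc34)cc2F)ccn1` gives 1300 nM. Compound 2 `CN(C)CCn1cnnc1-c1cc(Oc2ccc(NC(=O)N/N=C/c3ccccc3)cc2F)ccn1` gives 1120 nM in this assay, and compound 3 `CN(C)CCn1cnnc1-c1cc(Oc2ccc(NC(=O)N/N=C/c3ccc(F)cc3)cc2F)ccn1` gives 1370 nM. Compound 3 has the highest of the three numbers, but the steps that place it there are small: a 1.1-fold higher number from compound 1 to compound 3 (0.02 log units; within the scatter) and a 1.2-fold higher number from compound 2 to compound 3 (0.09 log units; within the scatter). The remaining pair is equally flat, a 1.2-fold lower number from compound 1 to compound 2 (0.06 log units; within the scatter).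

Compound 4 `CN(C)CCn1cnnc1-c1cc(Oc2ccc(NC(=O)N/N=C/c3ccc(O)c(O)c3)cc2F)ccn1` is unmeasured. Its change from compound 3 is 3,4-dihydroxyphenyl in place of 4-fluorophenyl on a carbon with a double bond to nitrogen. All three measured steps touch the same aryl position, and none of them moved the number beyond the scatter, whether the ring was swapped or a fluoro was added. Going by the values given here, no measured step exchanges a fluoro for hydroxyls, so the expectation rests on the flatness seen so far. In this assay compound 4 is therefore expected to show no step beyond the scatter, a 1.1-fold lower number from compound 3 to compound 4 (0.02 log units; within the scatter). The estimate for compound 4 is 1300 nM, with a range from 600 nM to 2900 nM.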

Compound 4, half-maximal inhibitory concentration: 1890 nM
Compound 4: the middle estimate sits 1.5-fold (0.16 log units) below what was measured; the measured number falls inside the stated range.
By their numbers in this assay, from the lowest: compounds 2, 1, 3 and 4 (each within the scatter of the next).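

Working notes on the aryl group on the carbon with a double bond to nitrogen, read in this assay: 3,4-dihydroxyphenyl is the first group here to carry hydroxyls, and its exchange for 4-fluorophenyl stays within the scatter (a 1.4-fold higher number from compound 3 to compound 4 (0.14 log units; within the scatter)). The same holds against the other two aryl groups (a 1.7-fold higher number from compound 2 to compound 4 (0.23 log units; within the scatter); a 1.5-fold higher number from compound 1 to compound 4 (0.16 log units; within the scatter)), so all four compounds remain flat at this place, and the flatness now extends to a ring bearing hydrogen-bond donors and acceptors. Nothing available explains this lack of response.

Open, from the compounds shown here alone, is whether a non-aromatic group on this carbon, such as a cyclohexyl ring or a longer alkyl chain, would move the number beyond the scatter. Also open, going by these compounds, is whether an aryl ring bearing an amine or a carboxylic acid would do so.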